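The compounds below may be only part of what the source reports. "The series", "measured", "known", "first", "only" and "open" are said of these compounds alone.

Compound 1 `Cc1cn(COCCO)c(=O)[nH]c1=O`: in a functional assay on L1210 cells (Mus musculus) for inhibition (on this read-out higher numbers stand for weaker inhibition and lower numbers for stronger inhibition), compound 1 gives only a limit, > 1000 ug/mL.
Compound 2 `O=c1[nH]c(=O)n(COCCO)cc1[N+](=O)[O-]`: in this assay compound 2 gives only a limit, > 1000 ug/mL.
Compound 3 `Nc1ccn(COCCO)c(=O)n1`: in this assay compound 3 gives only a limit, > 1000 ug/mL.

Compound 3 thus stands at a limit rather than a number, and so do the two other values, all three sitting at the limit of > 1000 ug/mL in this assay, at which 3 of the 3 values shown sit. Compound 4 `Nc1nc(=O)n(COCCO)cc1[N+](=O)[O-]` differs from compound 3 in one place: nitro in place of hydrogen on an aromatic carbon.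

Within the data shown here, one measured step bears on this change, a step that the two limits leave unreadable from compound 1 to compound 2, where a nitro group also enters the shared core; its size cannot be read, as both ends are limits. No step beyond the scatter can therefore be expected in this assay, and a further limit is the most likely outcome. Compound 4 is expected to give 1500 ug/mL, in the range 500 ug/mL to 5000 ug/mL. The expected step is a step that the limit leaves unreadable from compound 3 to compound 4.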

Compound 4, concentration for 50% inhibition: > 500 ug/mL
Compound 4: only a limit was reported; the forecaster's own chance of this, stated with the estimate: 85%; the middle value lies beyond the limit too.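

Compound 3 and compound 4 are both reported only as limits, so no step can be read for adding the nitro group. The compounds shown leave open how strongly, if at all, any of them inhibits in this assay, and whether a nitro group changes that.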